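Sulfo to Dimethylamino: An Expected Gain in Inhibition

This account rests on a few compounds, and the source may have more. Where it says the series, first, only, none or still open, it means among the compounds named here.

Compound 1 `O=C(O)c1cnc2cc(S(=O)(=O)O)ccc2c1O`: 2140000 nM
Compound 2 `O=C(O)c1cnc2cc(OCCOc3ccc(F)cc3)ccc2c1O`: 18200 nM

In an assay on isolated protein with malate dehydrogenase, mitochondrial (Sus scrofa) as the target (on this read-out higher numbers stand for weaker inhibition and lower numbers for stronger inhibition), compound 1 gives 2140000 nM, the higher of the two numbers shown, while compound 2 gives 18200 nM, a gap beyond the scatter. Compound 3 `CN(C)c1ccc2c(O)c(C(=O)O)cnc2c1` differs from compound 1 by dimethylamino in place of sulfo on an aromatic carbon. Among the measured compounds shown here, no measured pair covers this exact change, so the step is only expected: a move to a lower number of moderate size, an 11-fold lower number from compound 1 to compound 3 (1.03 log units; beyond the scatter), because compound 1 at 2140000 nM is the weakest point of the set. Compound 3 is estimated at 200000 nM, with a range from 30000 nM to 1500000 nM.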

Compound 3, half-maximal inhibitory concentration: 479000 nM
For compound 3 the middle estimate is 2.4-fold (0.38 log units) below the measured one; low and high end bracket the measured number.
By their numbers in this assay, from the lowest: compound 2; then compound 3; then compound 1.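

In this assay, among the compounds shown here, dimethylamino in place of sulfo on an aromatic carbon gives a 4.5-fold lower number from compound 1 to compound 3 (0.65 log units; beyond the scatter) and so provides the first measured single-place step at this position. It shows that inhibition here changes with the group on this carbon, even though the entering group is only a small one with no ring. Nothing measured here explains this gain. As far as these compounds go, whether a primary amine or a carboxylic acid on the same carbon would give a lower or a higher number remains open. So does the effect of replacing the methyl groups of dimethylamino with longer chains.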